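Two Cytotoxicity Values and One Compound Still to Measure

The source may hold more compounds than are shown below. What is called first, only, known or untested is meant among the compounds shown, and "the series" means these compounds.

Measured so far:
- compound 1, `COc1ccc2c(c1)[n+]([O-])c(C#N)c(-c1ccc(Cl)cc1)[n+]2[O-]`: 17500 nM
- compound 2, `Cc1ccc(-c2c(C#N)[n+]([O-])c3cc(C)ccc3[n+]2[O-])cc1`: 25000 nM

Both compounds were tested in an ADME assay on KB cells (Homo sapiens) for cytotoxicity, read by resazurin assay, with a stated time of 48 h; a higher number here means a weaker inhibitor, a lower number a stronger inhibitor. Compound 1 stands at one end of this very short list, and compound 2 sits within the scatter of it, so the two cannot be told apart on these numbers. For the measured compounds named here, no pair of measured compounds differing in a single place has been recorded, so nothing is yet known about how any one structural change moves the read-out.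

Compound 3, `COc1ccc2c(c1)[n+]([O-])c(C#N)c(-c1ccc(OC(F)(F)F)cc1)[n+]2[O-]`, has not been measured in this assay. It differs from compound 1 as follows: trifluoromethoxy in place of chloro on an aromatic carbon. The difference lies on one aromatic ring at the edge of the shared core, and the rest of the molecule is unchanged. Going by the values given here, since no measured pair shows this change, no direction can be read off for it. The expected step is a 1.1-fold higher number from compound 1 to compound 3 (0.06 log units; within the scatter), which lies within the scatter. Compound 3 is therefore estimated to give about 20000 nM, in a range from 7000 nM to 60000 nM.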

Compound 3, half-maximal inhibitory concentration: 8250 nM
Compound 3: middle estimate off by 2.4-fold (0.38 log units), on the high side, within the range that was stated.
By their numbers in this assay, from the lowest: compound 3; then compounds 1 and 2 (each within the scatter of the next).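

In this assay, for the compounds shown here, this is the first step between two measured compounds that differ in one place, and it shows that the group on this aromatic carbon, para to a large group, can shift the read-out: trifluoromethoxy in place of chloro gives a 2.1-fold lower number from compound 1 to compound 3 (0.33 log units; beyond the scatter) and so moves the series beyond the usual scatter, towards a stronger inhibitor. Going by these compounds alone, until now, the only comparison available was between two compounds that could not be told apart and that differ in more than one place, so no single change could be judged. The step is modest and rests on one pair, and nothing measured here explains why this exchange lowers the number.

Going by these compounds, it remains open how other groups would behave on this same carbon, such as an amine, a carboxylic acid, a longer alkyl chain or a simple methoxy group. On these data alone, it is also open whether the same exchange of chloro for trifluoromethoxy would give a similar step if the rest of the shared core carried different groups.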